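Swapping a hydroxy for a fluoro on the benzyl ring

A few compounds are considered here, and "the series" means these few. Any claim that something is new, unique, unknown or untested is made for them only; others in the source may bear on it.

Of the compounds shown here, three sharing one core have been tested in an ADME assay on Vero cells (Chlorocebus sabaeus) for cytotoxicity; a lower number here means a stronger inhibitor, a higher number a weaker inhibitor. Compound 1 `COc1ccc(Cn2cc(CNC(=O)c3ccc([N+](=O)[O-])o3)nn2)cc1F` gives 312000 nM. Compound 2 `COc1ccc(Cn2cc(CNC(=O)c3ccc([N+](=O)[O-])o3)nn2)cc1O` gives 174000 nM, and compound 3 `COc1cc(Cn2cc(CNC(=O)c3ccc([N+](=O)[O-])o3)nn2)ccc1O` gives 224000 nM. On these numbers compound 3 holds the second highest place of the three, yet neither neighbour lies beyond the scatter: a 1.3-fold higher number from compound 2 to compound 3 (0.11 log units; within the scatter), and a 1.4-fold lower number from compound 1 to compound 3 (0.14 log units; within the scatter).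

Compound 4 `COc1cc(Cn2cc(CNC(=O)c3ccc([N+](=O)[O-])o3)nn2)ccc1F` has not yet been measured. It differs from compound 3 in one place: fluoro in place of hydroxy on an aromatic carbon. The measured step that speaks most directly to this change runs the other way, hydroxy in place of fluoro, though at a different spot of the same ring: a 1.8-fold lower number from compound 1 to compound 2 (0.25 log units; within the scatter). Read in reverse, that step suggests that putting fluoro back in place of hydroxy would, if anything, raise the number slightly, and the step from compound 2 to compound 3 shows that moving the hydroxy around the ring changes little.

The expectation for compound 4 in this assay is therefore a small upward drift at most, a 1.3-fold higher number from compound 3 to compound 4 (0.13 log units; within the scatter), with no move beyond the usual scatter. Compound 4 is estimated at 300000 nM, within a range from 150000 nM to 600000 nM.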

Compound 4, half-maximal inhibitory concentration: 225000 nM
For compound 4 the middle estimate is 1.3-fold (0.12 log units) above the measured one, and the stated range covers the measured number.
By their numbers in this assay, from the lowest: compounds 2, 3, 4 and 1 (each within the scatter of the next).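

In this assay, the swap is now seen directly at the position ortho to a methoxy group and para to a large group, and hydroxy and fluoro there cannot be told apart (a 1.0-fold higher number from compound 3 to compound 4 (0.00 log units; within the scatter)). The 4-fluoro-3-methoxyphenyl group also stays within the scatter of the other two ring patterns, both the one carrying hydroxy (a 1.3-fold higher number from compound 2 to compound 4 (0.11 log units; within the scatter)) and the one carrying fluoro (a 1.4-fold lower number from compound 1 to compound 4 (0.14 log units; within the scatter)). The exchange of these two groups thus reads alike at the two ring spots, with no gap beyond the scatter between the two results: the same change on two cores in this assay, a 1.8-fold lower number (0.25 log units; within the scatter) from compound 1 to compound 2 and a 1.0-fold lower number (0.00 log units; within the scatter) from compound 4 to compound 3, 1.8-fold (0.25 log units) apart, within the scatter of two such steps.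

All four compounds sit within the scatter of one another, so they show no group on this ring that moves the number in this assay and give no basis for ranking fluoro against hydroxy at either spot. As far as these compounds go, whether an amine or a carboxylic acid at this position, or a longer chain in place of the methoxy group, would give a step beyond the scatter remains open.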